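Trading an open chain for a ring on compound 2

This account rests on a few compounds, and the source may have more. Where it says the series, first, only, none or still open, it means among the compounds named here.

Three related compounds have been tested in a functional assay on COLO 205 cells (Homo sapiens) for antiproliferative activity, read by luminescence, with a stated time of 72 h; a lower number here means a stronger inhibitor, a higher number a weaker inhibitor. Compound 1 (`Cc1cnc(Nc2ccnn2C)nc1-c1cn2c(c1F)CN([C@H](CO)c1cccc(Cl)c1)C2=O`) is reported as "not active" (no number reported), with no number attached. Compound 2 (`C[C@@H](CO)Nc1ncc(Cl)c(-c2cc3n(c2)C(=O)N([C@H](CO)c2cccc(Cl)c2)C3)n1`) gives 81 nM, and compound 3 (`Cc1cnc(Nc2ccnn2C)nc1-c1cc2n(c1)C(=O)N([C@H](CO)c1cccc(Cl)c1)CC2`) gives 77.1 nM. These two numbers lie within the usual scatter of each other, so compound 2 and compound 3 cannot be told apart in this assay, while compound 1 has no number to compare.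

The next compound, compound 4 (`O=C1N([C@H](CO)c2cccc(Cl)c2)Cc2cc(-c3nc(NC4CCOCC4)ncc3Cl)cn21`), keeps the rest of compound 2 and alters one group: oxan-4-yl in place of 1-(hydroxymethyl)ethyl on a nitrogen on an aromatic ring. In words, oxan-4-yl stands in place of 1-(hydroxymethyl)ethyl on a nitrogen on an aromatic ring, so a chain with no ring gives way to a six-membered non-aromatic ring.

Among the measured compounds shown here, no measured pair here shows this change on its own, so the expectation starts from compound 2 at 81 nM and stays cautious. The expected change is a 1.5-fold higher number from compound 2 to compound 4 (0.17 log units; within the scatter), a small move towards a weaker inhibitor that would probably not go beyond the scatter in this assay. For compound 4 the estimated value is 120 nM, with an expected range from 40 nM to 400 nM.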

Compound 4, half-maximal inhibitory concentration: 104 nM
Estimate against measurement, compound 4: 1.2-fold (0.06 log units) above; the range from low to high includes it.
By their numbers in this assay, from the lowest: compounds 3, 2 and 4 (each within the scatter of the next).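

Among the compounds shown here, on a nitrogen on an aromatic ring, the change from an open chain to a ring gives a 1.3-fold higher number from compound 2 to compound 4 (0.11 log units; within the scatter) in this assay, the first step between two measured compounds that differ in one place. The earlier compounds shown here could not isolate this position, but this pair shows that 1-(hydroxymethyl)ethyl, with its hydrogen-bond donor and defined stereocentre, and oxan-4-yl, with 0 hydrogen-bond donors and a six-membered non-aromatic ring, cannot be told apart here, so this one exchange leaves the antiproliferative reading unresolved from that of compound 2. No supporting data are available to explain why these two groups read alike.

Still open, as far as these compounds go, is how the reading would respond to a cyclohexyl group, which has carbon in place of the ring oxygen, to a piperidin-4-yl group, which has nitrogen there, or to a longer chain such as 3-hydroxypropyl at the same place. Also open, from the compounds shown here alone, is whether the same exchange would read alike on the different cores of compound 1 and compound 3, since this single pair cannot establish a general pattern.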